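Removing the Ring Substituent: Expected Antiproliferative Potency of Compound 4

A few compounds are considered here, and "the series" means these few. Any claim that something is new, unique, unknown or untested is made for them only; others in the source may bear on it.

Three compounds have been measured in a functional assay on MDA-MB-231 cells (Homo sapiens) for antiproliferative activity, read by WST assay, with a stated time of 72 h; on this read-out higher numbers stand for weaker inhibition and lower numbers for stronger inhibition:

compound 1, `CCCCCCCCCCCCCCCCCC/N=c1\nc(N)c2nc[nH]c2c(N)n1`, with 1430 nM
compound 2, `CCCCCCCC/N=c1\nc(N)c2ncn(Cc3ccccc3)c2c(N)n1`, with 4750 nM
compound 3, `CCCCCCCC/N=c1\nc(N)c2ncn(Cc3ccc(F)cc3)c2c(N)n1`, with 3600 nM

Compound 3 sits second highest of the three numbers. Its nearest neighbour is compound 2, which lies within the scatter of it; its furthest is compound 1, whose number is lower by a gap beyond the scatter. Among the compounds with values here, the only single-point step among the measured compounds, a 1.3-fold lower number from compound 2 to compound 3 (0.12 log units; within the scatter), concerns a fluoro on the benzyl ring and not the benzyl group itself.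

Compound 4, `CCCCCCCC/N=c1\nc(N)c2nc[nH]c2c(N)n1`, arises from compound 3 by hydrogen in place of 4-fluorobenzyl on an aromatic nitrogen. Within the data shown here, no measured step covers this change directly. Compound 1 also carries a hydrogen on that ring nitrogen, but it differs from compound 4 in the length of its chain. The value of compound 1, 1430 nM, therefore only shows that an unsubstituted ring nitrogen is compatible with activity in this range. With nothing to anchor the direction, compound 4 is expected to stay close to compound 3, the step of a 1.1-fold higher number from compound 3 to compound 4 (0.05 log units; within the scatter) being an estimate within or near the scatter. Compound 4 is therefore estimated at 4000 nM, with a range from 1500 nM to 12000 nM.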

Compound 4, half-maximal inhibitory concentration: "not active" (no number reported)
Compound 4 has no reported number here; the estimate stays without a comparison.
By their numbers in this assay, from the lowest: compound 1; then compounds 3 and 2 (each within the scatter of the next).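

In this assay, within the data shown here, compound 4 is reported as "not active", without a number, so no step from compound 3 to compound 4 can be read. No measured evidence bears on this result. The compounds shown leave open how much the 4-fluorobenzyl group on the ring nitrogen and the chain length each contribute to activity.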